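This account rests on a few compounds, and the source may have more. Where it says the series, first, only, none or still open, it means among the compounds named here.

Measured so far:

Compound 1 `CCn1c(=O)c2nc(-c3ccc(S(=O)(=O)N4CCSCC4)cc3)[nH]c2n(CC)c1=O` gives 36.6 nM in an assay for binding affinity to adenosine receptor A1 (Bos taurus); on this read-out lower numbers stand for stronger inhibition and higher numbers for weaker inhibition.

Compound 2 `Cn1c(=O)c2nc(-c3ccc4ccccc4c3)[nH]c2n(C)c1=O` gives 5.5 nM in this assay.

Of these two numbers, compound 1 carries the higher one and compound 2 the lower; the two compounds differ in more than one place, so the gap between them is not traced to any single change, and the values are taken only as they stand.

Compound 3 `CCn1c(=O)c2nc(-c3ccc(S(=O)(=O)NCCN(C)C)cc3)[nH]c2n(CC)c1=O` has not yet been measured in this assay. It keeps the core of compound 1 and differs from it in one place: (2-(dimethylamino)ethyl)amino in place of thiomorpholin-4-yl on a sulfonyl sulfur. For the measured compounds named here, nothing among the measured compounds separates this change from others, so no step of known size supports a prediction. The expectation for compound 3 rests on the value of compound 1 alone, and the step from compound 1 to compound 3 is expected to stay small, in either direction, and not clearly beyond the scatter: a 1.2-fold higher number from compound 1 to compound 3 (0.09 log units; within the scatter). Going by the values given here, compound 3 is therefore estimated at 45 nM, with a range from 15 nM to 150 nM; the range is wide, as no comparable step is at hand.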

Compound 3, half-maximal inhibitory concentration: 3.3 nM
For compound 3 the middle estimate is 14-fold (1.13 log units) above the measured one, outside the stated range (below it).
By their numbers in this assay, from the lowest: compounds 3 and 2 (each within the scatter of the next); then compound 1.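

In this assay the exchange of thiomorpholin-4-yl for (2-(dimethylamino)ethyl)amino on the sulfonyl sulfur gives an 11-fold lower number from compound 1 to compound 3 (1.04 log units; beyond the scatter) and shows that the group at this place can move the number well beyond the scatter while the core of compound 1 stays the same. The size of the step comes with no change in heavy-atom count: the ring leaves, a second nitrogen takes the place of the sulfur, and a hydrogen-bond donor enters. Nothing shown ties the step to any of these differences, and no measurement bears on its cause.

The compounds shown leave open which part of the change carries the step, whether the open chain, the sulfonamide hydrogen or the dimethylamino group. A (2-methoxyethyl)amino group on the same sulfonyl sulfur would bear on the role of the dimethylamino nitrogen, while a (3-(dimethylamino)propyl)amino chain or a 4-methylpiperazin-1-yl ring would bear on the role of chain length and of the open chain.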